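A few compounds are considered here, and "the series" means these few. Any claim that something is new, unique, unknown or untested is made for them only; others in the source may bear on it.

Compound 1 `Clc1ccc(Cn2cc(COc3ccccc3)nn2)cc1`, compound 2 `Clc1cccc(Cn2cc(COc3ccccc3)nn2)c1` and compound 3 `Cc1ccc(OCc2cn(Cc3ccc(Cl)cc3)nn2)cc1` were all tested in an ADME assay on PANC-1 cells (Homo sapiens) for inhibition, read by MTT assay, with a stated time of 48 h; a lower number here means a stronger inhibitor of growth, a higher number a weaker inhibitor of growth. In this assay compound 1 reached only the limit of the measurement and gives > 100 ug/mL. Compound 2 likewise reached only the limit and gives > 100 ug/mL. Compound 3 also reached only the limit, with > 100 ug/mL. Compound 2 differs from compound 1 by 3-chlorophenyl in place of 4-chlorophenyl on a saturated chain carbon bound to an aromatic nitrogen, and the measured step in this assay is a step that the two limits leave unreadable from compound 1 to compound 2. Compound 3 differs from compound 1 by methyl in place of hydrogen on an aromatic carbon, with a step that the two limits leave unreadable from compound 1 to compound 3. Compound 4 `Cc1ccc(OCc2cn(Cc3cccc(Cl)c3)nn2)cc1` has not yet been measured; it differs from compound 3 by 3-chlorophenyl in place of 4-chlorophenyl on a saturated chain carbon bound to an aromatic nitrogen, the same change as between compound 1 and compound 2, made at the same place. Because (the limit of > 100 ug/mL in this assay, at which 3 of the 3 values shown sit), all three measured compounds sit at the same limit, and the effect of this change cannot be read from them. The step from compound 3 to compound 4 is therefore expected to be a step that the limit leaves unreadable from compound 3 to compound 4, with the result most likely again a limit. Compound 4 is estimated to give 150 ug/mL in this assay, between 60 ug/mL and 400 ug/mL.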

Compound 4, concentration for 50% growth inhibition: > 100 ug/mL
Compound 4 was reported as a limit; the forecaster's own chance of this, stated with the estimate: 85%; the middle value lies beyond the limit too.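

In this assay compound 4 gives > 100 ug/mL, which is a limit and not a number. No step from compound 3 or compound 2 to compound 4 can be read, because the values coincide at that limit: the limit of > 100 ug/mL in this assay, at which 4 of the 4 values shown sit.

Going by these compounds, what stays open is how far either change, 3-chlorophenyl for 4-chlorophenyl or methyl for hydrogen, alters growth inhibition.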